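Chloro to trifluoromethyl, second instance on a different core

A few compounds are considered here, and "the series" means these few. Any claim that something is new, unique, unknown or untested is made for them only; others in the source may bear on it.

Measured so far:
compound 1 `COc1ccc(-c2nn(-c3ccccc3)cc2C(=O)/C=C\Nc2ccc(Cl)cc2)cc1`, 3890 nM
compound 2 `COc1ccc(-c2nn(-c3ccccc3)cc2C(=O)/C=C\Nc2ccc(C(F)(F)F)cc2)cc1`, > 50000 nM
compound 3 `COc1cc(-c2nn(-c3ccccc3)cc2C(=O)/C=C\Nc2ccc(Cl)cc2)cc(OC)c1OC`, 11200 nM

In a functional assay on PC-3 cells (Homo sapiens) for antiproliferative activity, read by MTT assay, with a stated time of 48 h (on this read-out lower numbers stand for stronger inhibition and higher numbers for weaker inhibition), compound 1 gives 3890 nM. For compound 2 the assay reports only a limit, > 50000 nM, not a number. The change between them is trifluoromethyl in place of chloro on an aromatic carbon, and the step it made is an at least 12-fold higher number from compound 1 to compound 2 (1.10 log units; beyond the scatter); its true size is open because of the limit of > 50000 nM in this assay, at which 1 of the 3 values shown sits.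

Compound 3 gives 11200 nM in this assay, the higher of the two numbers, with compound 1 nearest. How the core of compound 3 differs from the core of compound 1 is not broken down here.

Compound 4 `COc1cc(-c2nn(-c3ccccc3)cc2C(=O)/C=C\Nc2ccc(C(F)(F)F)cc2)cc(OC)c1OC` has not yet been measured. It differs from compound 3 by trifluoromethyl in place of chloro on an aromatic carbon, the same change as that from compound 1 to compound 2, made at the same place. With compound 3 already standing higher than compound 1 in this assay, the expected step is an 11-fold higher number from compound 3 to compound 4 (1.03 log units; beyond the scatter), resting on the size of an at least 12-fold higher number from compound 1 to compound 2 (1.10 log units; beyond the scatter). Compound 4 is therefore expected to reach the limit of the assay rather than a number. The estimate for compound 4 is 120000 nM, within 30000 nM to 500000 nM.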

Compound 4, half-maximal inhibitory concentration: > 50000 nM
Compound 4: only a limit was reported; the forecaster's own chance of this, stated with the estimate: 80%; the middle value is on the limit's open side.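

Carried onto the second core in this assay, trifluoromethyl in place of chloro again gives a step beyond the scatter and in the same direction, towards weaker inhibition, an at least 4.4-fold higher number from compound 3 to compound 4 (0.64 log units; beyond the scatter), and set beside the first instance this reads: the same change on two cores in this assay, an at least 12-fold higher number (1.10 log units; beyond the scatter) from compound 1 to compound 2 and an at least 4.4-fold higher number (0.64 log units; beyond the scatter) from compound 3 to compound 4; the limit leaves it open whether they differ

Compound 4 stands at a limit of the assay, > 50000 nM, and not at a number.

The direction of the change therefore carries from one core to the other in these two pairs, but its size does not transfer in any readable way, and the step between compound 2 and compound 4 cannot be read, so nothing follows about which of the two trifluoromethyl compounds is weaker: the limit of > 50000 nM in this assay, at which 2 of the 4 values shown sit.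

As far as these compounds go, only chloro and trifluoromethyl appear at this place on the aromatic ring, so it stays open whether fluoro, methyl, methoxy or a nitrile there would keep a measurable number on either core. Also open, from the compounds shown here alone, is whether the same direction would hold with a core carrying something other than the 4-methoxyphenyl or 3,4,5-trimethoxyphenyl group, such as a plain phenyl or a hydroxyphenyl.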